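The source may hold more compounds than are shown below. What is called first, only, known or untested is meant among the compounds shown, and "the series" means these compounds.

In a functional assay on HepG2 cells (Homo sapiens) for cytotoxicity, read by MTT assay, with a stated time of 24 h (on this read-out lower numbers stand for stronger inhibition and higher numbers for weaker inhibition), compound 1 (`CN1C/C(=C\c2cccnc2)C(=O)/C(=C/c2ccccc2F)C1`) gives 4810 nM, compound 2 (`CN1C/C(=C\c2cccnc2)C(=O)/C(=C/c2ccccc2C(F)(F)F)C1`) gives 2550 nM and compound 3 (`CN1C/C(=C\c2ccc(C#N)cc2)C(=O)/C(=C/c2cccnc2)C1`) gives 12700 nM. Compound 2 lies within the scatter of compound 1, and its number is below that of compound 3. The measured steps are a 1.9-fold lower number from compound 1 to compound 2 (0.28 log units; within the scatter) and a 2.6-fold higher number from compound 1 to compound 3 (0.42 log units; beyond the scatter). Next is compound 4 (`CN1C/C(=C\c2ccncc2)C(=O)/C(=C/c2ccccc2C(F)(F)F)C1`), with pyridin-4-yl in place of pyridin-3-yl on a double-bonded chain carbon bound to a double-bonded ring carbon. Neither measured step exchanges one pyridinyl for another, so both indicate only the size of steps seen so far. No shift beyond the scatter is expected in this assay. The expected change is a 1.1-fold higher number from compound 2 to compound 4 (0.04 log units; within the scatter). For compound 4 the estimate is 2800 nM, with an expected range of 1200 nM to 6500 nM.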

Compound 4, half-maximal inhibitory concentration: 3300 nM
Compound 4: middle estimate off by 1.2-fold (0.07 log units), on the low side; measured number inside the range.
By their numbers in this assay, from the lowest: compounds 2, 4 and 1 (each within the scatter of the next); then compound 3.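

In this assay, within the data shown here, pyridin-4-yl in place of pyridin-3-yl on a double-bonded chain carbon bound to a double-bonded ring carbon gives a 1.3-fold higher number from compound 2 to compound 4 (0.11 log units; within the scatter) and is the first exchange of one pyridinyl for another at this position. With the rest of the molecule unchanged, the assay does not separate these two groups. No measurement on hand speaks to the reason for this result. Going by these compounds, whether pyridin-2-yl or an aminophenyl group at this carbon would give a step beyond the scatter remains open. Also open, on these data alone, is whether the same pyridinyl exchange reads alike with the fluoro group of compound 1 in place of trifluoromethyl.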